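The compounds below may be only part of what the source reports. "The series", "measured", "known", "first", "only" and "open" are said of these compounds alone.

Compound 2 `Oc1ccccc1-c1cc(-c2ccoc2)cc(-c2ccccc2O)n1` carries a furan-3-yl group on the shared core. In a functional assay on HCT-15 cells (Homo sapiens) for cytotoxicity, read by CCK-8 assay (a higher number here means a weaker inhibitor, a lower number a stronger inhibitor), compound 2 gives > 50000 nM, which is a limit of the assay and not a number. Compound 1 `Oc1ccccc1-c1cc(-c2cccs2)cc(-c2ccccc2O)n1`, the thiophen-2-yl analogue, gives in this assay > 50000 nM, likewise a limit. Compound 3 `Oc1ccc(-c2cc(-c3ccoc3)cc(-c3ccccc3O)n2)cc1` gives in this assay > 50000 nM, again a limit. The steps a step that the two limits leave unreadable from compound 1 to compound 2 and a step that the two limits leave unreadable from compound 2 to compound 3 thus cannot be sized; what the series shows is the limit of > 50000 nM in this assay, at which 3 of the 3 values shown sit. Compound 4 `Oc1ccccc1-c1cc(-c2cccnc2)cc(-c2ccccc2O)n1` differs from compound 2 by pyridin-3-yl in place of furan-3-yl on an aromatic carbon. Within the data shown here, no measured step involves a pyridin-3-yl group, and neither measured step is readable, so no direction for this change can be drawn from the numbers. Compound 4 is nevertheless expected to sit at the limit as well because of the limit of > 50000 nM in this assay, at which 3 of the 3 values shown sit. The estimate for compound 4 in this assay is 50000 nM, between 20000 nM and 120000 nM. The expected step of a number no higher from compound 2 to compound 4 (the limit leaves the size open) is therefore none beyond the scatter, with the caveat that the starting value of compound 2 is itself only a limit.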

Compound 4, half-maximal inhibitory concentration: > 50000 nM
Compound 4: a limit, no number (the forecaster's own chance of this, stated with the estimate: 80%); the middle value lies on the limit itself.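

In this assay compound 4 gives > 50000 nM, a limit and not a number. The steps to compound 4 from compound 1 and from compound 2 therefore cannot be read. The compounds shown leave open whether any of these groups changes cytotoxicity, because every value stops at the same point: the limit of > 50000 nM in this assay, at which 4 of the 4 values shown sit.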